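The source may report more compounds than this note shows. Statements on the series, on what has been measured and on what is new or still open speak of the compounds shown alone.

Working notes on the series.

The shared core of compound 2 `Cc1cc(OCC(=O)O)cc2ccn(Cc3ccc(O)c(C(C)C)c3)c12` carries an oxyacetic acid and a methyl on the six-membered ring and a benzyl bearing a hydroxyl and an isopropyl on the ring nitrogen. Among the compounds with values here, in an assay on HeLa cells for displacement of a labelled ligand from thyroid hormone receptor alpha (Homo sapiens) (a higher number here means a weaker inhibitor, a lower number a stronger inhibitor), compound 2 gives 1.09 nM, the lowest of the three numbers so far. Compound 3 `Cc1cc(OCC(=O)O)cc2cc(C)n(Cc3ccc(O)c(C(C)C)c3)c12`, which adds a methyl on the five-membered ring, gives 2.05 nM in this assay; the step of a 1.9-fold higher number from compound 2 to compound 3 (0.27 log units; within the scatter) falls within the scatter. Within the data shown here, compound 1 `Cc1cn(Cc2ccc(O)c(C(C)C)c2)c2ccc(OCC(=O)O)cc12`, which lacks the methyl on the six-membered ring and carries its methyl elsewhere on the five-membered ring, gives 7.74 nM in this assay; it differs from compound 2 in two places, so no single step links them.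

Compound 4 `Cc1cn(Cc2ccc(O)c(C(C)C)c2)c2c(C)cc(OCC(=O)O)cc12` takes the change (methyl in place of hydrogen on an aromatic carbon). Among the measured compounds shown here, the only single step of the same kind is a 1.9-fold higher number from compound 2 to compound 3 (0.27 log units; within the scatter), which stayed within the scatter; the higher number of compound 1 argues for a slight loss. Compound 4 is therefore expected to give 1.9 nM in this assay, within 0.7 nM to 5 nM, the expected step of a 1.7-fold higher number from compound 2 to compound 4 (0.24 log units; within the scatter) being small.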

Compound 4, inhibition constant: 2.77 nM
Estimate against measurement, compound 4: 1.5-fold (0.16 log units) below; the range from low to high includes it.
By their numbers in this assay, from the lowest: compounds 2, 3 and 4 (each within the scatter of the next, the first and the last beyond it); then compound 1.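

In this assay, a methyl on the five-membered aromatic ring, two ring bonds from the ring nitrogen, gives a 2.5-fold higher number from compound 2 to compound 4 (0.41 log units; beyond the scatter), whereas the methyl elsewhere on that ring gave a 1.9-fold higher number from compound 2 to compound 3 (0.27 log units; within the scatter); compound 3 and compound 4 lie within the scatter of each other, so the two places are not told apart. A methyl on the six-membered ring, the change that links the other pair, runs the opposite way and gives a 2.8-fold lower number from compound 1 to compound 4 (0.45 log units; beyond the scatter). The same change therefore carries no single direction across these cores: the same change on two cores in this assay, a 1.9-fold higher number (0.27 log units; within the scatter) from compound 2 to compound 3 and a 2.8-fold lower number (0.45 log units; beyond the scatter) from compound 1 to compound 4, 5.3-fold (0.72 log units) apart, beyond the scatter of two such steps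

Open, from the compounds shown here alone, is how the core with hydrogen at both of these places would read. Also open, going by these compounds, is whether a longer chain, an amine or a carboxylic acid at this position would be tolerated as the methyl is.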